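The source may report more compounds than this note shows. Statements on the series, on what has been measured and on what is new or still open speak of the compounds shown alone.

In a functional assay on Vas deferens for antagonist activity at Alpha-1A adrenergic receptor (Rattus norvegicus) (on this read-out higher numbers stand for higher potency (the scale is a negative logarithm) and lower numbers for lower potency), compound 1 `COc1cccc(OC)c1OCCNCCOc1ccccc1OCc1ccc(Cl)cc1` gives 8.17, and compound 2 `COc1cccc(OC)c1OCCNCCOc1ccccc1OCc1ccc(C)cc1` gives 8.23. Going by the values given here, the step of a number 0.06 log units higher from compound 1 to compound 2 (within the scatter) leaves the two within the scatter of each other, so compound 2 stands level with the only other measured compound rather than apart from it. Compound 3 `COc1cccc(OC)c1OCCNCCOc1ccccc1OCc1cccc([N+](=O)[O-])c1` carries 3-nitrophenyl in place of 4-methylphenyl on a saturated chain carbon bound to an oxygen on an aromatic ring. Among the compounds with values here, the one measured step, which exchanged one group for another at the same place, changed little; a nitro group has no measured precedent here. The step of a number 0.23 log units lower from compound 2 to compound 3 (within the scatter) is therefore expected to be small. The estimate for compound 3 is 8, with a range from 7.4 to 8.6.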

Compound 3, negative logarithm of the antagonist equilibrium constant: 8.85
Compound 3: middle estimate off by 0.85 log units, on the low side; the measured number lies above the stated range.
By their numbers in this assay, from the lowest: compounds 1 and 2 (each within the scatter of the next); then compound 3.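

In this assay, this position proves sensitive to what the ring carries: 3-nitrophenyl gives a number 0.62 log units higher from compound 2 to compound 3 (beyond the scatter) in place of 4-methylphenyl and a number 0.68 log units higher from compound 1 to compound 3 (beyond the scatter) in place of 4-chlorophenyl. The earlier exchange of chloro for methyl showed no such separation, as it stayed within the scatter. No evidence at hand accounts for this rise.

On these data alone, the nitro group and the place of the substituent on the ring change together here, so the share of each remains open. As far as these compounds go, how an amine or a carboxylic acid on that ring would read is also open.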